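Swapping a Nitrile Chain for a Chlorophenyl Ring

A few compounds are considered here, and "the series" means these few. Any claim that something is new, unique, unknown or untested is made for them only; others in the source may bear on it.

Among the compounds with values here, compound 2 `Cc1cc(C)c(Oc2cc(Nc3ccc(C#N)cc3)ncc2C(=O)NCc2cn(CCC#N)nn2)c(C)c1` carries the only definite number here: in an ADME assay on MT4 cells (Homo sapiens) for cytotoxicity, read by MTT assay, with a stated time of 5 days (a higher number here means that more compound is tolerated, a lower number that less compound is tolerated), compound 2 gives 40200 nM. Compound 1 `Cc1cc(C)c(Oc2cc(Nc3ccc(C#N)cc3)ncc2C(=O)NCc2cn(Cc3ccc(Cl)cc3)nn2)c(C)c1` reaches only a limit of the assay, >= 120000 nM. Within the data shown here, the one measured step, an at least 2.9-fold lower number from compound 1 to compound 2 (0.47 log units; beyond the scatter), starts from that limit (the limit of >= 120000 nM in this assay, at which 1 of the 2 values shown sits). Compound 3 `Cc1cc(C)c(Oc2cc(Nc3ccc(C#N)cc3)ncc2C(=O)NCc2cn(Cc3ccccc3Cl)nn2)c(C)c1` differs from compound 2 by 2-chlorophenyl in place of cyanomethyl on a saturated chain carbon bound to an aromatic nitrogen, a change of the same kind as the measured step but run the other way, so a higher number is expected. Compound 3 is expected to show a 2.5-fold higher number from compound 2 to compound 3 (0.40 log units; beyond the scatter). Compound 3 is estimated at 100000 nM, with a range from 40000 nM to 200000 nM.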

Compound 3, half-maximal cytotoxic concentration: >= 188000 nM
Compound 3: no number, only a limit; the forecaster's own chance of this, stated with the estimate: 50%; middle value at least 1.8-fold (0.27 log units) from the limit.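

Replacing the nitrile chain with a second kind of chlorophenyl group gives an at least 4.6-fold higher number from compound 2 to compound 3 (0.66 log units; beyond the scatter) in this assay, so the earlier step was not peculiar to the 4-chlorophenyl group of compound 1. Compound 3 gives >= 188000 nM, which is a limit of the assay and not a number. Compound 1 and compound 3 both stand at limits, and the step between them cannot be read.

From the compounds shown here alone, whether moving the chlorine changes tolerance therefore stays open. So does what a plain benzyl group without chlorine, or a chain ending in an amine, would give at this place.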